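The compounds below may be only part of what the source reports. "The series", "measured", "known", "first", "only" and "open" are said of these compounds alone.

Of the compounds shown here, three sharing one core have been tested. In a functional assay on HepG2 cells (Homo sapiens) for antiproliferative activity, read by MTT assay, with a stated time of 48 h (on this read-out lower numbers stand for stronger inhibition and higher numbers for weaker inhibition), compound 1 `CC(=O)N1N=C(c2ccc3ccccc3c2)OC1c1cccc(Br)c1` gives 1.68 ug/mL. Compound 2 `CC(=O)N1N=C(c2ccc3ccccc3c2)OC1c1ccc(Cl)cc1` gives 1.88 ug/mL, and compound 3 `CC(=O)N1N=C(c2ccc3ccccc3c2)OC1c1ccccc1[N+](=O)[O-]` gives 12.3 ug/mL. Compound 1 has the lowest number of the three, though its gap to compound 2 is too small to rank them: a 1.1-fold higher number from compound 1 to compound 2 (0.05 log units; within the scatter). Against compound 3 the gap is clear: a 7.3-fold higher number from compound 1 to compound 3 (0.86 log units; beyond the scatter), and likewise a 6.5-fold higher number from compound 2 to compound 3 (0.82 log units; beyond the scatter).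

Compound 4 `CC(=O)N1N=C(c2ccc3ccccc3c2)OC1c1ccccc1O` has not yet been measured. It differs from compound 1 in one place: 2-hydroxyphenyl in place of 3-bromophenyl on a saturated ring carbon. Two of the measured steps bear on this change. Swapping one halogen-bearing phenyl for another left the number essentially unchanged, while putting a substituent on the ring position seen in compound 3 raised the number beyond the scatter. Going by the values given here, the hydroxyl of compound 4 sits on that same position, so a modest rise in the number is the expectation, a 3.6-fold higher number from compound 1 to compound 4 (0.55 log units; beyond the scatter), with no measured step giving a closer precedent. Compound 4 is therefore estimated at 6 ug/mL, within a range from 2 ug/mL to 20 ug/mL.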

Compound 4, half-maximal inhibitory concentration: 1.84 ug/mL
Compound 4: the middle estimate sits 3.3-fold (0.51 log units) above what was measured; the measured number lies below the stated range.
By their numbers in this assay, from the lowest: compounds 1, 4 and 2 (each within the scatter of the next); then compound 3.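

A substituent on this phenyl ring does not by itself raise the number in this assay. With 2-hydroxyphenyl on the saturated ring carbon, the number stays level with both halogen-bearing compounds (a 1.1-fold higher number from compound 1 to compound 4 (0.04 log units; within the scatter); a 1.0-fold lower number from compound 2 to compound 4 (0.01 log units; within the scatter)), so the higher number of compound 3 is not shared by every compound with a group at the 2-position of this phenyl ring. The identity of that group matters, as hydroxy in place of nitro shows (a 6.7-fold lower number from compound 3 to compound 4 (0.83 log units; beyond the scatter)), and the hydrogen-bond donor that 2-hydroxyphenyl brings in place of 3-bromophenyl leaves the number within the scatter.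

As far as these compounds go, whether 2-aminophenyl or 2-methoxyphenyl would sit with compound 4 or with compound 3 remains open. No measurement given here explains the gap between compound 3 and compound 4.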